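Working notes: from compound 3 to compound 4

The source may report more compounds than this note shows. Statements on the series, on what has been measured and on what is new or still open speak of the compounds shown alone.

Values measured in an ADME assay on Vero cells (Chlorocebus sabaeus) for cytotoxicity, read by MTT assay, with a stated time of 96 h; a lower number here means that less compound is tolerated, a higher number that more compound is tolerated
compound 1 `CC(=O)c1ccc2[nH]c(-c3ccccc3)nc2c1` gives > 100000 nM (a limit)
compound 2 `COc1ccc(-c2nc3cc(/C(C)=N/O)ccc3[nH]2)c(OC)c1` gives > 100000 nM (a limit)
compound 3 `CC(=O)c1ccc2c(c1)nc(-c1ccccc1)n2C1CCCCC1` gives 80000 nM (a number)

For the measured compounds named here, compound 3 stands at 80000 nM as the only actual number here. Compound 1 and compound 2 stand at the limit of > 100000 nM in this assay, at which 2 of the 3 values shown sit, as limits only.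

Compound 4 `CC(=O)c1ccc2c(c1)nc(-c1ccc(C(F)(F)F)cc1)n2C1CCCCC1` differs from compound 3 by trifluoromethyl in place of hydrogen on an aromatic carbon as its change: trifluoromethyl in place of hydrogen on an aromatic carbon, para to a large group.

Going by the values given here, the only measured step is an at least 1.2-fold lower number from compound 1 to compound 3 (0.09 log units; that floor lies within the scatter) and it concerns cyclohexyl in place of hydrogen on an aromatic nitrogen, a different place from the new change. It sets no size for trifluoromethyl. Among the compounds with values here, with only that step to go on, no step beyond the scatter is expected in this assay, with a 1.5-fold lower number from compound 3 to compound 4 (0.16 log units; within the scatter) as the estimated change. For compound 4 the estimate is 55000 nM as the expected value, with an expected range from 20000 nM to 100000 nM and a limit reading also possible.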

Compound 4, half-maximal cytotoxic concentration: 35000 nM
For compound 4 the middle estimate is 1.6-fold (0.20 log units) above the measured one, and the stated range covers the measured number.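

Trifluoromethyl in place of hydrogen on an aromatic carbon, para to a large group, gives in this assay a 2.3-fold lower number from compound 3 to compound 4 (0.36 log units; beyond the scatter), the only step here beyond the scatter, whereas the floor of the cyclohexyl step, an at least 1.2-fold lower number from compound 1 to compound 3 (0.09 log units; that floor lies within the scatter), lies within it. This place on the six-membered aromatic ring of carbon only therefore responds to substitution, with less compound tolerated once trifluoromethyl is present, though the step is modest. With compound 3 and compound 4 both read as numbers, this pair can be sized, which the limit readings do not allow: the limit of > 100000 nM in this assay, at which 2 of the 4 values shown sit.

Going by these compounds, whether a single fluorine, an amine or a carboxylic acid at the same place would move the number in the same direction stays open, as does the size of the trifluoromethyl step on the core of compound 1 without cyclohexyl. What in trifluoromethyl accounts for the step cannot be told from these values.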